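The source may hold more compounds than are shown below. What is called first, only, known or untested is meant among the compounds shown, and "the series" means these compounds.

Compound 1 `O=C(CNc1ccccc1)N[C@H]1CCOC1=O` was tested in a functional assay on DU-145 cells (Homo sapiens) for antiproliferative activity, read by MTT assay, with a stated time of 72 h; a lower number here means a stronger inhibitor, a higher number a weaker inhibitor. Its value is a limit of the assay: compound 1 gives > 64000 nM. Compound 2 `O=C(CNc1ccccc1Cl)N[C@H]1CCOC1=O` also reaches only a limit, giving > 64000 nM. Compound 3 `O=C(CNc1cccc(Cl)c1)N[C@H]1CCOC1=O` likewise stops at a limit, with > 64000 nM. The steps a step that the two limits leave unreadable from compound 1 to compound 2 and a step that the two limits leave unreadable from compound 1 to compound 3 cannot be sized, because of the limit of > 64000 nM in this assay, at which 3 of the 3 values shown sit. Compound 4 `O=C(CNc1ccc(Br)cc1)N[C@H]1CCOC1=O` differs from compound 1 by bromo in place of hydrogen on an aromatic carbon. The two measured steps, each a halogen entering the aromatic ring, left the limit in place, so no readable change is expected here either, and compound 4 is expected to sit at or beyond that same limit, with an estimated step that the limit leaves unreadable from compound 1 to compound 4. The estimate for compound 4 is 100000 nM, within 40000 nM to 300000 nM.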

Compound 4, half-maximal inhibitory concentration: > 64000 nM
Compound 4: a limit, no number; the forecaster's own chance of this, stated with the estimate: 85%; the middle value is on the limit's open side.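

Compound 4 also stops at a limit, so its step from compound 1 cannot be read: the limit of > 64000 nM in this assay, at which 4 of the 4 values shown sit. The compounds shown leave open how far past that limit each lies in this assay.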